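Fluoro to methoxy swap carried across two core arrangements

The compounds below may be only part of what the source reports. "The series", "measured", "known", "first", "only" and "open" are said of these compounds alone.

Of the compounds shown here, three have been measured in an assay on isolated protein for inhibition of DNA topoisomerase 1 (Homo sapiens), with a stated time of 30 min, tested at 100 uM; on this read-out higher numbers stand for a stronger effect at the one concentration tested and lower numbers for a weaker effect. Compound 1 `COc1cccc(-c2nc3ccc(C)cc3c(=O)[nH]2)c1` gives 71.8%, compound 2 `Cc1ccc2nc(-c3cccc(F)c3)[nH]c(=O)c2c1` gives 82.9%, and compound 3 `Cc1ccc2c(=O)[nH]c(-c3cccc(F)c3)nc2c1` gives 77.5%. Compounds 2 and 3 are built from the same atoms joined differently; the difference between the two cores is not broken down here, and their values lie within the scatter of each other. Compound 1 is compound 2 with methoxy in place of fluoro on an aromatic carbon, and that step comes out as a number 11.1 percentage points lower from compound 2 to compound 1 (beyond the scatter).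

Compound 4 `COc1cccc(-c2nc3cc(C)ccc3c(=O)[nH]2)c1` stands to compound 3 as compound 1 stands to compound 2: methoxy in place of fluoro on an aromatic carbon. The description of the place is the same word for word in both cases, so this is the same kind of change, made on the core of compound 3 rather than on the core of compound 2. The change occurs twice among these compounds, and only one instance has a measurement.

The step expected here is a number 11.5 percentage points lower from compound 3 to compound 4 (beyond the scatter), set beside the measured one of a number 11.1 percentage points lower from compound 2 to compound 1 (beyond the scatter), and it rests on that single instance together with compound 3 giving 77.5% close to compound 2. Whether the step carries over from one core to the other cannot be checked against anything else in the series. Compound 4 is estimated at 66%, with an expected range from 54% to 78%.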

Compound 4, a percentage reported as inhibition, at one concentration (the size of the read-out at that concentration, not a potency): 100%
The estimate for compound 4 lay 34 percentage points below the measured number; the whole stated range lies below it.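

On the core of compound 3, methoxy in place of fluoro on an aromatic carbon gives a number 22.5 percentage points higher from compound 3 to compound 4 (beyond the scatter) in this assay, so the result of this change cannot be assumed to stay the same when the core is rearranged. Set against the earlier step, the two results point in opposite directions, and the gap between them is larger than the scatter allows: the same change on two cores in this assay, a number 11.1 percentage points lower (beyond the scatter) from compound 2 to compound 1 and a number 22.5 percentage points higher (beyond the scatter) from compound 3 to compound 4, 33.6 percentage points apart, beyond the scatter of two such steps. This shows that, among these four compounds, the outcome of the swap depends on the core that carries it, but with one pair on each core it does not show why, nor does it give a rule that would hold for other changes or other cores.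

The aromatic ring in question carries only fluoro or methoxy in the compounds shown, so it remains open whether chloro, hydroxy or an amine in that place would also respond differently on the two cores. Also open, going by these compounds, is how these compounds would compare at other concentrations, since each read-out here gives the size of the effect at a single tested concentration and not a potency.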